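Ortho substitution on the N-aryl ring of a pyridopyrimidinone amide

The source may hold more compounds than are shown below. What is called first, only, known or untested is meant among the compounds shown, and "the series" means these compounds.

Compound 2 `O=C(Nc1ccc(Oc2ccnc3[nH]ccc23)cc1)c1cc2cccnc2n(-c2ccc(Br)cc2F)c1=O` gives the highest of the two numbers measured in a functional assay on A549 cells (Homo sapiens) for antiproliferative activity, read by MTT assay, with a stated time of 72 h (on this read-out higher numbers stand for weaker inhibition and lower numbers for stronger inhibition), at 1570 nM. For the measured compounds named here, compound 1 `O=C(Nc1ccc(Oc2ccnc3[nH]ccc23)cc1)c1cc2cccnc2n(-c2ccc(Br)cc2)c1=O` gives 280 nM in this assay, and the only step, a 5.6-fold higher number from compound 1 to compound 2 (0.75 log units; beyond the scatter), is a fluoro in place of hydrogen on an aromatic carbon. Compound 3 `O=C(Nc1ccc(Oc2ccnc3[nH]ccc23)cc1)c1cc2cccnc2n(-c2ccc(C(F)(F)F)cc2Cl)c1=O` carries 2-chloro-4-(trifluoromethyl)phenyl in place of 4-bromo-2-fluorophenyl on an aromatic nitrogen. Going by the values given here, no measured step covers this double exchange, so the expected step of a 1.3-fold higher number from compound 2 to compound 3 (0.11 log units; within the scatter) is small and uncertain. Compound 3 is therefore estimated at 2000 nM, expected between 500 nM and 8000 nM.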

Compound 3, half-maximal inhibitory concentration: 3230 nM
For compound 3 the middle estimate is 1.6-fold (0.21 log units) below the measured one, within the range that was stated.
By their numbers in this assay, from the lowest: compound 1; then compound 2; then compound 3.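

In this assay the exchange of 4-bromo-2-fluorophenyl for 2-chloro-4-(trifluoromethyl)phenyl gives a 2.1-fold higher number from compound 2 to compound 3 (0.31 log units; beyond the scatter), so the number climbs further at this position on an aromatic nitrogen. Against the plain 4-bromophenyl, the same group gives a 12-fold higher number from compound 1 to compound 3 (1.06 log units; beyond the scatter), a large step. Both aryl groups with a second ring substituent now stand on the weaker side of compound 1.

No evidence at hand bears on why these numbers rise. The compounds shown leave open how an amine or a carboxylic acid on this aryl ring would read, and whether chloro and trifluoromethyl each contribute alone.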